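The compounds below may be only part of what the source reports. "The series", "measured", "known", "first", "only" and "open" are said of these compounds alone.

The series rests on a shared core, seen in compound 1 `CC1=CC[C@H](C(C)(C)N=C=S)CC1`, the simplest member. In a functional assay on UACC-62 cells (Homo sapiens) for inhibition, read by sulforhodamine B assay, with a stated time of 48 h (on this read-out lower numbers stand for stronger inhibition of growth and higher numbers for weaker inhibition of growth), compound 1 gives "not determined" (no result reported). Compound 2 `CC1=CC[C@H](C(C)(C)NC(=S)N/N=C/c2ccccc2)CC1` extends that core by a larger arm ending in an unsubstituted benzene ring. In this assay compound 2 gives > 100000 nM, which is a limit of the assay rather than a number. Compound 2 therefore stands at the top of what the numbers shown can tell, a point described by the limit of > 100000 nM in this assay, at which 1 of the 2 values shown sits; of the two entries, one is this limit and the other carries no number at all. Compound 3 `COc1ccc(/C=N/NC(=S)NC(C)(C)[C@H]2CC=C(C)CC2)cc1` differs from compound 2 in one place: methoxy in place of hydrogen on an aromatic carbon. Within the data shown here, no step between measured compounds is available, so nothing here calibrates the size of such a change. One expects the step from compound 2 to compound 3 to be a number no higher from compound 2 to compound 3 (the limit leaves the size open), which is none beyond the scatter. Compound 3 is therefore estimated at 100000 nM, within a range from 30000 nM to 300000 nM, and most likely reported again only as a limit.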

Compound 3, concentration for total growth inhibition: 70400 nM
Compound 3: middle estimate off by 1.4-fold (0.15 log units), on the high side, and the stated range covers the measured number.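

In this assay, among these compounds, compound 3 gives 70400 nM, the first single number, so the arm ending in 4-methoxyphenyl offers a fixed point against which further changes can be read, something neither earlier compound provided. Methoxy in place of hydrogen on an aromatic carbon, para to a large group, gives an at least 1.4-fold lower number from compound 2 to compound 3 (0.15 log units; that floor lies within the scatter), so the two compounds show no change beyond the scatter, though a larger one is not ruled out. As far as these compounds go, the true size of the step stays open because compound 2 is held only by a limit: the limit of > 100000 nM in this assay, at which 1 of the 3 values shown sits.

From the compounds shown here alone, with one group at one position, it remains open whether a hydroxyl group, a chlorine atom, an amine or a carboxylic acid in the same place would move the number further, and whether a longer chain such as ethoxy would do more than methoxy. It is also open whether methoxy elsewhere on the ring would give the same result, and the step from the shared core to the larger arm cannot be read from the compounds shown.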